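The source may report more compounds than this note shows. Statements on the series, on what has been measured and on what is new or still open speak of the compounds shown alone.

Compound 1 `O=c1cc(Cn2cc(CCCO)nn2)c2ccc(O)cc2o1`: 90200 nM
Compound 2 `CC(C)(C)c1cn(Cc2cc(=O)oc3cc(O)ccc23)nn1`: 81100 nM
Compound 3 `O=c1cc(Cn2cc(-c3cc(F)cc(F)c3)nn2)c2ccc(O)cc2o1`: 27600 nM

In a functional assay on HeLa cells (Homo sapiens) for inhibition, read by MTT assay, with a stated time of 72 h (on this read-out lower numbers stand for stronger inhibition and higher numbers for weaker inhibition), compound 1 stands highest of the three numbers; its nearest neighbour is reached by a 1.1-fold lower number from compound 1 to compound 2 (0.05 log units; within the scatter) and its furthest by a 3.3-fold lower number from compound 1 to compound 3 (0.51 log units; beyond the scatter). Compound 4 `O=c1cc(Cn2cc(CSC(=S)N3CCNCC3)nn2)c2ccc(O)cc2o1` differs from compound 1 by a group of 9 heavy atoms (5 carbon, 2 nitrogen, 2 sulfur; one six-membered non-aromatic ring with 2 hetero atoms) in place of a group of 3 heavy atoms (2 carbon, 1 oxygen; no ring), on a saturated chain carbon bound to an aromatic carbon. For the measured compounds named here, no measured step touches this part of the chain; the steps that exist exchange groups on an aromatic carbon, one within the scatter and two modest ones, among them a 2.9-fold lower number from compound 2 to compound 3 (0.47 log units; beyond the scatter). Going by the values given here, the change to compound 4 is larger than any of those, and the data give no step of its kind. A modest shift toward a lower number, estimated as a 2.3-fold lower number from compound 1 to compound 4 (0.35 log units; beyond the scatter), is expected. Compound 4 is expected to give 40000 nM, with a range from 10000 nM to 120000 nM.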

Compound 4, half-maximal inhibitory concentration: > 100000 nM
Compound 4: only a limit was reported; the forecaster's own chance of this, stated with the estimate: 10%; middle value at least 2.5-fold (0.39 log units) away from the limit.
By their numbers in this assay, from the lowest: compound 3; then compounds 2 and 1 (each within the scatter of the next). At a limit, above all of these: compound 4.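

For compound 4, this assay returns only a limit, not a number: the limit of > 100000 nM in this assay, at which 1 of the 4 values shown sits.
At this saturated chain carbon bound to an aromatic carbon, the exchange reads as an at least 1.1-fold higher number from compound 1 to compound 4 (0.04 log units; that floor lies within the scatter) and so gives no lower number than compound 1 shows, despite the added six-membered non-aromatic ring. That floor lies within the scatter, so how far compound 4 stands from compound 1 cannot be read.

The compounds shown leave open whether a simple amine, a carboxylic acid or a longer chain at this place would lower the number.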